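Compound 3: hydrogen for methyl on an aromatic carbon

A few compounds are considered here, and "the series" means these few. Any claim that something is new, unique, unknown or untested is made for them only; others in the source may bear on it.

In a functional assay on MIA PaCa-2 cells (Homo sapiens) for antiproliferative activity, read by sulforhodamine B assay, with a stated time of 48 h (a higher number here means a weaker inhibitor, a lower number a stronger inhibitor), compound 1 `COc1cc(OC)c2sc(-c3ccc(N/C=C\C(=O)c4ccc(OC)c(O)c4)cc3)nc2c1` gives 11600 nM as its reading, and compound 2 `COc1cc(OC)c2sc(-c3ccc(N/C=C\C(=O)c4ccc(OC)c(F)c4)c(C)c3)nc2c1` gives 16300 nM as its reading. Within the data shown here, these two values lie within the scatter of each other, so compound 2 stands level with compound 1 on the numbers so far.

Compound 3 `COc1cc(OC)c2sc(-c3ccc(N/C=C\C(=O)c4ccc(OC)c(F)c4)cc3)nc2c1` is still unmeasured and differs from compound 2 in one place (hydrogen in place of methyl on an aromatic carbon): hydrogen in place of methyl on an aromatic carbon, ortho to a large group and meta to a large group. Among the measured compounds shown here, no measured pair isolates this change, so its size has no direct precedent here. For the measured compounds named here, the only guide is the close agreement of the two readings already in hand, and that supports no firm direction. In this assay the expected change (a 1.3-fold lower number from compound 2 to compound 3 (0.10 log units; within the scatter)) is therefore none beyond the scatter. The estimate for compound 3 is 13000 nM as the expected value, with an estimated range of 6000 nM to 28000 nM for the reading.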

Compound 3, half-maximal inhibitory concentration: 4300 nM
Estimate against measurement, compound 3: 3.0-fold (0.48 log units) above, outside the stated range (below it).
By their numbers in this assay, from the lowest: compound 3; then compounds 1 and 2 (each within the scatter of the next).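

Hydrogen in place of methyl on this aromatic carbon, ortho to a large group and meta to a large group, gives a 3.8-fold lower number from compound 2 to compound 3 (0.58 log units; beyond the scatter) in this assay, which shows that the series is sensitive to a methyl group at this position. A second single change also registers: fluoro in place of hydroxy on an aromatic carbon gives a 2.7-fold lower number from compound 1 to compound 3 (0.43 log units; beyond the scatter), a modest step beyond the scatter, with no methyl on the position above in either compound. The data in hand offer no measurement that accounts for either step.

Going by these compounds, whether the response at this aromatic carbon is specific to methyl or extends to other groups, such as chloro, methoxy or an amine, remains open, since hydrogen and methyl are the only two substituents compared here. Also open, on these data alone, is whether the fluoro-for-hydroxy step keeps its direction and size when the methyl group is present, and whether a chloro group or an amine in that place would read like fluoro or like hydroxy.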